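From isopropyl to oxan-4-yl on a carbonyl carbon

This account rests on a few compounds, and the source may have more. Where it says the series, first, only, none or still open, it means among the compounds named here.

Compound 1 `CC(C)C(=O)N1N=CCC1c1ccccc1`: > 1.5 h
Compound 2 `N#Cc1nccc(N2CCC(C(=O)N3N=CC[C@H]3c3cc(F)cc(F)c3)CC2)n1`: 2.1 h

Both compounds were tested in an ADME assay on microsomes (Homo sapiens) for metabolic stability; a higher number here means that the compound lasts longer, a lower number that the compound disappears faster. There compound 1 gives > 1.5 h, and this is a limit of the assay, not a number. Compound 1 thus stands at the limit of > 1.5 h in this assay, at which 1 of the 2 values shown sits. Compound 2 gives 2.1 h, which is a measured number. For the measured compounds named here, no two measured compounds differ in one place only, so no measured step is available as a guide.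

Compound 3 `O=C(C1CCOCC1)N1N=CCC1c1ccccc1` has not yet been measured. It differs from compound 1 by oxan-4-yl in place of isopropyl on a carbonyl carbon, with oxan-4-yl in place of isopropyl on a carbonyl carbon, while the rest of the structure stays the same. No change beyond the usual scatter of this assay is expected in either direction, so a step that the limit leaves unreadable from compound 1 to compound 3 is expected to be small. Compound 3 may also be reported only as a limit. As a number, the half-life of compound 3 is estimated at 1.8 h, with an expected range from 0.8 h to 3.5 h.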

Compound 3, half-life: > 1.5 h
Compound 3 was reported as a limit; the forecaster's own chance of this, stated with the estimate: 45%; the middle value lies beyond the limit too.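

In this assay compound 3 gives > 1.5 h as a limit of the assay and not a number. Compound 1 is likewise reported only as a limit, and no step can be read between compound 1 and compound 3. The compounds shown leave open whether oxan-4-yl in place of isopropyl on a carbonyl carbon alters the half-life at all.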